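Ethoxy for Methoxy: What to Expect for Compound 3

The source may hold more compounds than are shown below. What is called first, only, known or untested is meant among the compounds shown, and "the series" means these compounds.

Compound 2 `COc1nc(-c2nc3ccccc3n2C)cc(-c2cccs2)c1C#N` and compound 1 `CCOc1nc(-c2nc3ccccc3n2C)cc(-c2ccc(Cl)cc2)c1C#N` have both been tested in a functional assay on aorta (Rattus norvegicus, strain Wister); a lower number here means a stronger inhibitor, a higher number a weaker inhibitor. Compound 2 stands at 312000 nM, and compound 1 gives 293000 nM, a number that lies within the scatter of the first. Compound 3 `CCOc1nc(-c2nc3ccccc3n2C)cc(-c2cccs2)c1C#N` awaits measurement in this assay. It differs from compound 2 by methyl in place of hydrogen on a saturated chain carbon bound to an oxygen on an aromatic ring. Among the compounds with values here, no measured pair shows this change, so a step of a 1.0-fold lower number from compound 2 to compound 3 (0.02 log units; within the scatter) is expected, one that stays within the scatter with no direction favored. Compound 3 is therefore estimated at 300000 nM, in a range from 120000 nM to 750000 nM.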

Compound 3, half-maximal inhibitory concentration: 249000 nM
Compound 3: the middle estimate sits 1.2-fold (0.08 log units) above what was measured; the measured number falls inside the stated range.
By their numbers in this assay, from the lowest: compounds 3, 1 and 2 (each within the scatter of the next).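

In this assay, within the data shown here, compound 3 gives the first measured pair for methoxy to ethoxy on this core, a step of a 1.3-fold lower number from compound 2 to compound 3 (0.10 log units; within the scatter) for methyl in place of hydrogen on a saturated chain carbon bound to an oxygen on an aromatic ring. Among these compounds, it also gives the first pair for thiophen-2-yl in place of 4-chlorophenyl on an aromatic carbon, with a step of a 1.2-fold lower number from compound 1 to compound 3 (0.07 log units; within the scatter) at that second place. Nothing at hand bears on the reason for either result.

On these data alone, whether a longer chain, such as propoxy, or an amine at the oxygen-bearing place would move the number beyond the scatter remains open.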